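The source may hold more compounds than are shown below. What is called first, only, known or untested is meant among the compounds shown, and "the series" means these compounds.

Working notes on the dibenzoylhydrazine series. Among the compounds with values here, compound 3 `CC(C)(C)N(NC(=O)c1ccccc1I)C(=O)c1ccccc1Cl` gives 1290 nM in an assay on cells for agonist activity at ecdysone receptor (Bombyx mori), read by a luciferase reporter, with a stated time of 24 h (on this read-out higher numbers stand for an effect only at larger amounts of compound and lower numbers for an effect already at smaller amounts), the highest of the three numbers so far; compound 1 `CC(C)(C)N(NC(=O)c1ccccc1)C(=O)c1ccccc1Br` gives 170 nM and compound 2 `Cc1cc(C)cc(C(=O)N(NC(=O)c2ccccc2)C(C)(C)C)c1` gives 69.2 nM, both well away from compound 3. The next compound is compound 4 `CC(C)(C)N(NC(=O)c1ccc(Cl)cc1)C(=O)c1ccccc1Cl`, which differs from compound 3 in one place: 4-chlorophenyl in place of 2-iodophenyl on a carbonyl carbon.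

Within the data shown here, only one measured step exists, a 2.5-fold lower number from compound 1 to compound 2 (0.39 log units; beyond the scatter), a modest lowering on exchanging an aryl group, but it sits on the other carbonyl, the one bonded to the nitrogen that carries the tert-butyl group, so it bears on the present change only loosely. Among the measured compounds shown here, compound 3 and compound 1 differ in two places and give no single step. For the measured compounds named here, what the values show is that compound 3, the only compound with a 2-iodophenyl on the carbonyl next to the amide-type nitrogen, is the weakest of the three, and that a 2-bromophenyl elsewhere in compound 1 is tolerated.

On that basis a lowering is expected for compound 4, a 6.5-fold lower number from compound 3 to compound 4 (0.81 log units; beyond the scatter), beyond the scatter but with wide uncertainty. The estimate for compound 4 in this assay is 200 nM, with a range from 60 nM to 700 nM.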

Compound 4, half-maximal effective concentration: 115 nM
For compound 4 the middle estimate is 1.7-fold (0.24 log units) above the measured one, within the range that was stated.
By their numbers in this assay, from the lowest: compounds 2, 4 and 1 (each within the scatter of the next, the first and the last beyond it); then compound 3.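

In this assay, within the data shown here, the place on a carbonyl carbon whose other neighbours are the amide-type nitrogen responds strongly to the aryl group it carries: the exchange gives an 11-fold lower number from compound 3 to compound 4 (1.05 log units; beyond the scatter), a large step, whereas the one earlier step, a 2.5-fold lower number from compound 1 to compound 2 (0.39 log units; beyond the scatter), was modest and lay at a different place. The change is also tightly matched in what can be counted, since 2-iodophenyl and 4-chlorophenyl have the same number of heavy atoms, neither has hydrogen-bond donors or acceptors, and neither carries a net charge, so these counts do not separate the two groups even though the read-out does. Nothing measured here bears on the origin of this step.

From the compounds shown here alone, the step exchanges the halogen and its place on the ring together, so it remains open whether the iodine-to-chlorine exchange, the new place on the ring, or both together carry the effect, a question that a 4-iodophenyl group at this place would help to settle. Also open, going by these compounds, is how far the trend extends beyond halogens, for example to a 4-methoxyphenyl or a 4-aminophenyl group at the same place.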